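Swapping the Side Chain on a Poorly Soluble Core

The source may hold more compounds than are shown below. What is called first, only, known or untested is meant among the compounds shown, and "the series" means these compounds.

The measured compounds and their values:
Compound 1, `Cc1cc(/C=C/C#N)cc(C)c1Oc1cc(Nc2ccc(C#N)cc2)c(N)cc1C(F)(F)F`: 0.24 ug/mL
Compound 2, `Cc1cc(/C=C/C#N)cc(C)c1Oc1cc(Nc2ccc(C#N)cc2)c(N)cc1[N+](=O)[O-]`: 0.29 ug/mL
Compound 3, `Cc1cc(/C=C/C#N)cc(C)c1Oc1cc(Nc2ccc(C#N)cc2)c(N)cc1C(N)=O`: 0.63 ug/mL

These three were tested in a physicochemical assay for solubility, with a stated time of 4 h, at pH 7.4; on this read-out higher numbers stand for higher solubility and lower numbers for lower solubility. Compound 1 stands lowest of the three numbers; its nearest neighbour is compound 2, with a 1.2-fold higher number from compound 1 to compound 2 (0.08 log units; within the scatter), and its furthest is compound 3, with a 2.6-fold higher number from compound 1 to compound 3 (0.42 log units; beyond the scatter). Between the other two, a 2.2-fold higher number from compound 2 to compound 3 (0.34 log units; beyond the scatter). All three steps concern one aromatic carbon of the shared core, where trifluoromethyl, nitro or carbamoyl sits, and all stay modest.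

The new compound, compound 4, `CC(=O)CCc1cc(C)c(Oc2cc(Nc3ccc(C#N)cc3)c(N)cc2C(F)(F)F)c(C)c1`, changes a different part of the molecule: 2-acetylethyl in place of 2-cyanoethenyl on an aromatic carbon. Among the measured compounds shown here, none of the measured steps touches this side chain, so no measured step bears directly on the change from compound 1 to compound 4. The measured steps show that single-group changes on this core have moved solubility only modestly; with the same core retained in compound 4, a step of similar or smaller size is the reasonable expectation, without a clear direction. The expected step is therefore a 1.5-fold higher number from compound 1 to compound 4 (0.16 log units; within the scatter). For compound 4 the estimated solubility is 0.35 ug/mL, with a range from 0.12 ug/mL to 1 ug/mL.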

Compound 4, solubility: 0.16 ug/mL
Beside the measured number, compound 4's estimate is 2.2-fold (0.34 log units) above it; low and high end bracket the measured number.
By their numbers in this assay, from the lowest: compounds 4, 1 and 2 (each within the scatter of the next); then compound 3.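

Among the compounds shown here, compound 4 gives the first reading at this position, the aromatic carbon para to a large group and meta to two methyl groups, where the earlier compounds all carry 2-cyanoethenyl. In this assay, putting 2-acetylethyl in place of 2-cyanoethenyl gives a 1.5-fold lower number from compound 1 to compound 4 (0.18 log units; within the scatter), so this one exchange does not separate the two compounds, even though the chain that enters has one more heavy atom, swaps nitrogen for oxygen and loses the triple bond. Nothing shown here offers an explanation for this outcome.

On these data alone, a single pair says little about the position as a whole, so it remains open whether an amine, a carboxylic acid or a longer chain at this carbon would give a step beyond the scatter. Also open, as far as these compounds go, is whether 2-acetylethyl would give a similar result on a core carrying carbamoyl or nitro in place of trifluoromethyl, the two other groups seen at that separate aromatic carbon.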